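Amide-end variation in the shared core series

The source may hold more compounds than are shown below. What is called first, only, known or untested is meant among the compounds shown, and "the series" means these compounds.

Compound 1 `CCN(CC)C(=O)CN(c1cc(Cl)ccc1OC)S(=O)(=O)c1ccccc1` carries a diethylamino group on the carbonyl carbon. In a functional assay on SH-SY5Y cells (Homo sapiens), read by MTT assay, with a stated time of 24 h (a higher number here means that more compound is needed for the effect, a lower number that less compound is needed), compound 1 gives only the limit > 20000 nM. Compound 2 `COc1ccc(Cl)cc1N(CC(=O)Nc1ccccc1)S(=O)(=O)c1ccccc1` has anilino in place of diethylamino on the carbonyl carbon, and in this assay compound 2 likewise gives the limit > 20000 nM. Compound 3 `COc1ccc(CNC(=O)CN(c2cc(Cl)ccc2OC)S(=O)(=O)c2ccccc2)cc1` carries (4-methoxybenzyl)amino on the carbonyl carbon, and in this assay compound 3 also reaches only the limit > 20000 nM. All three values sit at the same point, (the limit of > 20000 nM in this assay, at which 3 of the 3 values shown sit), so compound 3 stands nowhere in particular among them. The steps a step that the two limits leave unreadable from compound 1 to compound 2, a step that the two limits leave unreadable from compound 1 to compound 3 and a step that the two limits leave unreadable from compound 2 to compound 3 accordingly have no readable size. Compound 4 `COc1ccccc1NC(=O)CN(c1cc(Cl)ccc1OC)S(=O)(=O)c1ccccc1` differs from compound 3 by 2-methoxyphenyl in place of 4-methoxybenzyl on an amide-type nitrogen. The measured steps that change the group on the carbonyl carbon or on the amide-type nitrogen cannot be read, so no direction is expected beyond the scatter, and a further limit is the most likely outcome. Compound 4 is therefore expected to stay at or near the limit, with an estimated 30000 nM and a range from 8000 nM to 120000 nM. The step that the limit leaves unreadable from compound 3 to compound 4 is the expected size.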

Compound 4, half-maximal effective concentration: 15500 nM
Compound 4: middle estimate off by 1.9-fold (0.29 log units), on the high side; measured number inside the range.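

In this assay compound 4 is the only compound shown that gives a number instead of a limit, so (2-methoxyphenyl)amino on the carbonyl carbon is the first group at this position with a readable value: the limit of > 20000 nM in this assay, at which 3 of the 4 values shown sit.

Methoxy in place of hydrogen on an aromatic carbon gives an at least 1.2-fold lower number from compound 2 to compound 4 (0.11 log units; that floor lies within the scatter), 2-methoxyphenyl in place of 4-methoxybenzyl on the amide-type nitrogen gives an at least 1.2-fold lower number from compound 3 to compound 4 (0.11 log units; that floor lies within the scatter), and (2-methoxyphenyl)amino in place of diethylamino gives an at least 1.2-fold lower number from compound 1 to compound 4 (0.11 log units; that floor lies within the scatter). Each of these floors lies within the scatter, so no step beyond it is shown, and the steps among compounds 1, 2 and 3 cannot be read.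

Going by these compounds, the true size of these steps stays open, as does whether the methoxy group itself carries the result. A hydroxy group or a chlorine in place of that methoxy would test this.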